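This account rests on a few compounds, and the source may have more. Where it says the series, first, only, none or still open, it means among the compounds named here.

In a functional assay on SNB-75 cells (Homo sapiens) for inhibition, read by sulforhodamine B assay, with a stated time of 48 h, tested at 10 uM (on this read-out higher numbers stand for more inhibition at the one concentration tested (going by the name of the read-out) and lower numbers for less inhibition), compound 3 `c1ccc2c(-c3cn4ccnc4c(-c4ccc5ncn(C6CCCCC6)c5c4)n3)cccc2c1` gives 16.5%, the second highest of three numbers. Compound 1 `c1ccc(-c2cn3ccnc3c(-c3ccc4ncn(C5CCCCC5)c4c3)n2)cc1` gives 44.4%, and compound 2 `COc1ccc(-c2cn3ccnc3c(-c3ccc4ncn(C5CCCCC5)c4c3)n2)cc1` gives -26.3%. The steps between them are a number 27.9 percentage points lower from compound 1 to compound 3 (beyond the scatter), a number 70.7 percentage points lower from compound 1 to compound 2 (beyond the scatter) and a number 42.8 percentage points higher from compound 2 to compound 3 (beyond the scatter). Compound 4 `Fc1ccc(-c2cn3ccnc3c(-c3ccc4ncn(C5CCCCC5)c4c3)n2)cc1` differs from compound 3 by 4-fluorophenyl in place of naphthalen-1-yl on an aromatic carbon. For the measured compounds named here, two measured steps bear on this: returning from naphthalen-1-yl to phenyl reverses the modest drop seen from compound 1 to compound 3, while adding a group to that phenyl ring caused the large drop from compound 1 to compound 2. Weighing both, a modest rise, a number 13.5 percentage points higher from compound 3 to compound 4 (beyond the scatter), is expected. Compound 4 is therefore estimated at 30%, with a range from -10% to 60%.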

Compound 4, a percentage reported as inhibition, at one concentration (the size of the read-out at that concentration, not a potency): 21%
Beside the measured number, compound 4's estimate is 9 percentage points above it, and the stated range covers the measured number.
By their numbers in this assay, from the lowest: compound 2; then compounds 3 and 4 (each within the scatter of the next); then compound 1.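

At this position, 4-fluorophenyl in place of naphthalen-1-yl gives a number 4.5 percentage points higher from compound 3 to compound 4 (within the scatter) so these two groups cannot be told apart here, though one carries two rings and the other one. On the phenyl ring, fluoro in place of hydrogen gives a number 23.4 percentage points lower from compound 1 to compound 4 (beyond the scatter) and fluoro in place of methoxy gives a number 47.3 percentage points higher from compound 2 to compound 4 (beyond the scatter) so the result depends on which group sits there, not only on a group being present. Nothing available explains these differences. Still open, on these data alone, is whether an amine or a carboxylic acid on that ring would follow fluoro or methoxy, or would exceed unsubstituted compound 1.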